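A few compounds are considered here, and "the series" means these few. Any claim that something is new, unique, unknown or untested is made for them only; others in the source may bear on it.

Measured so far in a functional assay on B16-F10 cells (Mus musculus) for antiproliferative activity, read by MTT assay, with a stated time of 48 h; a lower number here means a stronger inhibitor, a higher number a weaker inhibitor:
compound 1 `Cc1ccc(NCc2cn(-c3ccccc3)nc2-c2ccc(C)cc2)cc1` gives 7380 nM
compound 2 `Cc1ccc(-c2nn(-c3ccccc3)cc2CNc2ccc(F)cc2)cc1` gives 5670 nM
compound 3 `Cc1ccc(NCc2cn(-c3ccccc3)nc2-c2ccc(Br)cc2)cc1` gives 5980 nM

For the measured compounds named here, all three numbers lie close together; no step among them reaches beyond the usual scatter. Compound 2 arises from compound 1 by fluoro in place of methyl on an aromatic carbon and the step is a 1.3-fold lower number from compound 1 to compound 2 (0.11 log units; within the scatter). Compound 3 arises from compound 1 by bromo in place of methyl on an aromatic carbon and the step is a 1.2-fold lower number from compound 1 to compound 3 (0.09 log units; within the scatter). The values of compound 2 and compound 3 show no separation of note.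

Compound 4 `Fc1ccc(NCc2cn(-c3ccccc3)nc2-c2ccc(Br)cc2)cc1` is not yet measured. It arises from compound 3 by fluoro in place of methyl on an aromatic carbon. This is the same change that leads from compound 1 to compound 2, made here on the core of compound 3, which differs from the core of compound 1 by bromo in place of methyl on an aromatic carbon. Since that earlier step stayed within the scatter, a step of similar size is expected from compound 3 to compound 4, namely a 1.2-fold lower number from compound 3 to compound 4 (0.10 log units; within the scatter). On that basis compound 4 is estimated at 4800 nM in this assay, expected between 2500 nM and 9500 nM.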

Compound 4, half-maximal inhibitory concentration: 4180 nM
Compound 4: middle estimate off by 1.1-fold (0.06 log units), on the high side, within the range that was stated.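

In this assay, the change from 4-methylphenyl to 4-fluorophenyl gives a 1.4-fold lower number from compound 3 to compound 4 (0.16 log units; within the scatter), in line with the earlier step on the other core: the same change on two cores in this assay, a 1.3-fold lower number (0.11 log units; within the scatter) from compound 1 to compound 2 and a 1.4-fold lower number (0.16 log units; within the scatter) from compound 3 to compound 4, 1.1-fold (0.04 log units) apart, within the scatter of two such steps. Bromo in place of methyl gives a 1.4-fold lower number from compound 2 to compound 4 (0.13 log units; within the scatter), and this also agrees with its earlier counterpart: the same change on two cores in this assay, a 1.2-fold lower number (0.09 log units; within the scatter) from compound 1 to compound 3 and a 1.4-fold lower number (0.13 log units; within the scatter) from compound 2 to compound 4, 1.1-fold (0.04 log units) apart, within the scatter of two such steps. For the compounds shown here, both changes therefore carry from one core to the other without a detectable difference, but every step here lies within the scatter, so this shows only that neither change moves the number measurably on these two cores; it does not show that either change has a real effect that adds up, nor that the agreement extends beyond these four compounds.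

On these data alone, it remains open whether a methoxy group, an amine or a carboxylic acid in place of the methyl, fluoro or bromo would move the number beyond the scatter. Also open, as far as these compounds go, is how changes elsewhere on the shared core would behave, such as an amide in place of the amine link.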